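Triazene series: dropping the aryl methyl from compound 3

The source may hold more compounds than are shown below. What is called first, only, known or untested is meant among the compounds shown, and "the series" means these compounds.

Measured in an ADME assay on MT4 cells (Homo sapiens) for cytotoxicity, read by MTT assay, with a stated time of 96 h; on this read-out higher numbers stand for lower toxicity in this test and lower numbers for higher toxicity in this test:
- compound 1 `CN(/N=N/c1ccccc1)c1ccccc1`: 55000 nM
- compound 2 `CN(C)CCCN(/N=N/c1ccccc1)c1cccc(C(F)(F)F)c1`: 14000 nM
- compound 3 `Cc1ccc(/N=N/N(CCCN(C)C)c2ccccc2)cc1`: 18000 nM

Compound 3 holds the second highest of the three numbers in this assay. Its value and that of compound 2 lie within the scatter of each other, so nothing separates them. Compound 1 sits apart, with a higher number than compound 3 by a margin beyond the scatter.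

Compound 4 `CN(C)CCCN(/N=N/c1ccccc1)c1ccccc1` carries the dimethylaminopropyl chain of compound 3 but differs as follows: hydrogen in place of methyl on an aromatic carbon. Put another way, 4-methylphenyl becomes phenyl.

Among the measured compounds shown here, no step between measured pairs is available to size this change. The expectation for this assay is a step from compound 3 to compound 4 of a 1.2-fold higher number from compound 3 to compound 4 (0.07 log units; within the scatter), most likely none beyond the scatter, perhaps leaning slightly toward the higher number of compound 1 55000 nM. Compound 4 is therefore estimated at 21000 nM, within 9000 nM to 48000 nM.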

Compound 4, half-maximal cytotoxic concentration: 33000 nM
The estimate for compound 4 lay 1.6-fold (0.20 log units) below the measured number, and the stated range covers the measured number.
By their numbers in this assay, from the lowest: compounds 2, 3, 4 and 1 (each within the scatter of the next, the first and the last beyond it).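

In this assay, hydrogen in place of methyl gives a 1.8-fold higher number from compound 3 to compound 4 (0.26 log units; within the scatter), so this change does not separate the pair, while hydrogen in place of trifluoromethyl gives a 2.4-fold higher number from compound 2 to compound 4 (0.37 log units; beyond the scatter), a modest step. Placing 2-(dimethylamino)ethyl on the saturated chain carbon, read in the direction a 1.7-fold lower number from compound 1 to compound 4 (0.22 log units; within the scatter), likewise stays unresolved. No measurement available here explains these steps.

Open, as far as these compounds go, is whether a methoxy group or a chlorine atom on the same aromatic carbon would move the number. Also open, from the compounds shown here alone, is how a longer chain in place of the dimethylaminopropyl chain would read.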